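The source may report more compounds than this note shows. Statements on the series, on what has been measured and on what is new or still open speak of the compounds shown alone.

Three compounds have been measured in a functional assay (spleen, spleen) for activation, with Mus musculus as the target; on this read-out lower numbers stand for an effect already at smaller amounts and higher numbers for an effect only at larger amounts of compound:

Compound 1 `Nc1ncnc2c1nc(Cl)n2Cc1ccccc1`: the assay returned only a limit here, > 10 uM.
Compound 2 `Nc1nc(SCc2ccccc2)nc2c1nc(O)n2Cc1ccccc1`: 0.1 uM.
Compound 3 `Nc1ncnc2c1nc(O)n2Cc1ccc(F)cc1`: 10 uM.

Of the two results that are numbers, compound 2 gives the lowest. The nearest is compound 3, whose number lies higher, far beyond the usual scatter of repeated measurements. Compound 1 sits at the limit of > 10 uM in this assay, at which 1 of the 3 values shown sits, so for it there is a limit and no number.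

Compound 4 `CCCOc1nc(N)c2nc(O)n(Cc3ccccc3)c2n1` has not yet been measured. It differs from compound 2 in a single place: propoxy in place of benzylsulfanyl on an aromatic carbon. Among the measured compounds shown here, no pair of measured compounds differs by a change of this kind, so the size of the step cannot be read from the data; compound 3, which carries nothing at this place, shows a far higher number than compound 2, and that is the only pointer. The expectation is therefore a modest move, if any, towards a higher number. The step from compound 2 to compound 4 is estimated as a 2.0-fold higher number from compound 2 to compound 4 (0.30 log units; within the scatter). Compound 4 is expected at 0.2 uM. Its likely range is estimated to run from 0.03 uM to 1 uM.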

Compound 4, minimum effective concentration: 0.01 uM
Compound 4: middle estimate off by 20-fold (1.30 log units), on the high side; the whole stated range lies above it.
By their numbers in this assay, from the lowest: compound 4; then compound 2; then compound 3.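

Swapping benzylsulfanyl for propoxy on the aromatic carbon between two ring nitrogen atoms gives a 10-fold lower number from compound 2 to compound 4 (1.00 log units; beyond the scatter) in this assay, the first change at this place alone whose size can be read. It shows that this place responds strongly to what it carries, and that benzylsulfanyl, with its six-membered aromatic ring, is not needed here for an effect at small amounts, as propoxy, which has no ring, gives the lower number. Nothing measured here explains why the number falls with this change.

From the compounds shown here alone, the two groups differ at once in the linking atom, in chain length and in the ring, so which of these matters stays open. A propylsulfanyl group, a butoxy chain or a propylamino group at this place would help to separate them.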